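This account rests on a few compounds, and the source may have more. Where it says the series, first, only, none or still open, it means among the compounds named here.

In a functional assay on MCF7 cells (Homo sapiens) for cytotoxicity, read by MTT assay, with a stated time of 24 h (a lower number here means a stronger inhibitor, a higher number a weaker inhibitor), compound 3, `Cc1cc(-c2nc3cc(Cl)ccc3o2)ccc1NC(=O)CN1CCN(CCN(C)C)CC1`, gives 39300 nM, the highest number of the three measured compounds. Compound 1, `Cc1cc(-c2nc3cc(F)ccc3o2)ccc1NC(=O)CN1CCN(CCCN(C)C)CC1`, gives 7770 nM in this assay. Compound 2, `CN(C)CCCN1CCN(CC(=O)Nc2ccc(-c3nc4cc(Cl)ccc4o3)cc2)CC1`, gives 1650 nM in this assay. Both compound 1 and compound 2 carry the 3-(dimethylamino)propyl chain on the ring nitrogen, and both sit well below compound 3, by gaps that lie beyond the scatter.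

Compound 4, `Cc1cc(-c2nc3cc(Cl)ccc3o2)ccc1NC(=O)CN1CCN(CCCN(C)C)CC1`, has not yet been measured. It differs from compound 3 in one place: (dimethylamino)methyl in place of dimethylamino on a saturated chain carbon, two bonds along the chain from an amine nitrogen in a ring. Read one bond further out, the change is 2-(dimethylamino)ethyl to 3-(dimethylamino)propyl, which gives compound 4 the same chain that compound 1 and compound 2 carry.

On that basis a lowering step beyond the scatter is expected, estimated at a 6.6-fold lower number from compound 3 to compound 4 (0.82 log units; beyond the scatter). Compound 4 is expected to give about 6000 nM in this assay, within a range from 2000 nM to 20000 nM, because compound 1 with the same chain gives 7770 nM.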

Compound 4, half-maximal inhibitory concentration: 63400 nM
The estimate for compound 4 lay 11-fold (1.02 log units) below the measured number; measured number above the stated range.
By their numbers in this assay, from the lowest: compound 2; then compound 1; then compounds 3 and 4 (each within the scatter of the next).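

In this assay, 3-(dimethylamino)propyl in place of 2-(dimethylamino)ethyl comes with a 1.6-fold higher number from compound 3 to compound 4 (0.21 log units; within the scatter), so this chain change does not separate the two compounds. With that chain held constant, the number still moves at two other places: methyl in place of hydrogen on an aromatic carbon comes with a 38-fold higher number from compound 2 to compound 4 (1.58 log units; beyond the scatter), and chloro in place of fluoro on an aromatic carbon comes with an 8.2-fold higher number from compound 1 to compound 4 (0.91 log units; beyond the scatter). The 3-(dimethylamino)propyl chain shared by compound 1 and compound 2 therefore does not by itself give their lower numbers.

No measurement shown here bears on why these steps have the sizes they do. From the compounds shown here alone, it remains open whether a longer chain or a diethylamino end would change the number, and whether the methyl and chloro steps would keep their sizes with the 2-(dimethylamino)ethyl chain.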